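A few compounds are considered here, and "the series" means these few. Any claim that something is new, unique, unknown or untested is made for them only; others in the source may bear on it.

Series so far, in a functional assay on MDA-MB-231 cells (Homo sapiens) for inhibition, read by MTT assay, with a stated time of 72 h; on this read-out higher numbers stand for weaker inhibition and lower numbers for stronger inhibition:
- compound 1 `CC(C)=CCC[C@H](C)c1ccc(C)c(CNCCO)c1O`: 14400 nM
- compound 2 `CC(C)=CCC[C@H](C)c1ccc(C)c(CNCC2CCNCC2)c1O`: 18300 nM
- compound 3 `CC(C)=CCC[C@H](C)c1ccc(C)c2c1OCN(CCCCCO)C2`: 5400 nM

Compound 2 and compound 1 lie within the scatter of each other, while compound 3 has a lower number, beyond the scatter. Next is compound 4 `CC(C)=CCC[C@H](C)c1ccc(C)c(CNCCCCCO)c1O`, with the change (4-hydroxybutyl in place of piperidin-4-yl on a saturated chain carbon bound to an amine nitrogen), that is, 4-hydroxybutyl in place of piperidin-4-yl on a saturated chain carbon bound to an amine nitrogen.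

Among the measured compounds shown here, the one measured step at this place, a 1.3-fold higher number from compound 1 to compound 2 (0.10 log units; within the scatter), stays within the scatter. Compound 3, on a different core, also bears 5-hydroxypentyl and gives 5400 nM, so a modest fall is expected, the estimated step being a 1.8-fold lower number from compound 2 to compound 4 (0.26 log units; within the scatter). For compound 4 the expected value is 10000 nM, estimated range 5000 nM to 19000 nM.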

Compound 4, half-maximal inhibitory concentration: 10700 nM
Compound 4: middle estimate off by 1.1-fold (0.03 log units), on the low side; measured number inside the range.
By their numbers in this assay, from the lowest: compounds 3, 4, 1 and 2 (each within the scatter of the next, the first and the last beyond it).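

In this assay the steps are a 1.7-fold lower number from compound 2 to compound 4 (0.23 log units; within the scatter) for 4-hydroxybutyl in place of piperidin-4-yl and a 1.3-fold lower number from compound 1 to compound 4 (0.13 log units; within the scatter) for 3-hydroxypropyl in place of hydroxy, both within the scatter. At this position on the shared core, neither removing the ring nor extending the hydroxyalkyl chain to 5-hydroxypentyl separates these three compounds. No evidence bears on why these numbers stay so close.

Open, from the compounds shown here alone, is whether a carboxylic acid or a primary amine at the chain end would move the number beyond the scatter. Going by these compounds, a chain longer than 5-hydroxypentyl also remains untested here.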